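A few compounds are considered here, and "the series" means these few. Any claim that something is new, unique, unknown or untested is made for them only; others in the source may bear on it.

Series notes, cytotoxicity. Compound 1 `Cc1ccc(-c2ccc3[nH]c(=O)nc(-c4ccccc4)c3c2)cn1` in an ADME assay on L6 cells (Rattus norvegicus) for cytotoxicity, read by fluorescence and resazurin assay, with a stated time of 72 h (a lower number here means that less compound is needed, a higher number that more compound is needed for the effect), gives > 50000 nM, which is a limit of the assay and not a number. Compound 2 `O=c1nc(-c2ccccc2)c2cc(-c3ccc(N4CCCC4)nc3)ccc2[nH]1` likewise gives > 50000 nM, again a limit. Compound 3 `O=c1nc(-c2ccccc2)c2cc(-c3ccccc3F)ccc2[nH]1` gives a number, 55800 nM. The two measured steps from compound 1, a step that the two limits leave unreadable from compound 1 to compound 2 and a step that the limit leaves unreadable from compound 1 to compound 3, cannot be sized, because the limit of > 50000 nM in this assay, at which 2 of the 3 values shown sit, caps what either comparison can show. Compound 4 `O=c1nc(-c2ccccc2)c2cc(-c3cccc(F)c3)ccc2[nH]1` carries the change (3-fluorophenyl in place of 6-methylpyridin-3-yl on an aromatic carbon). Both measured steps from compound 1 exchange the same position without producing a readable change, so no step beyond the scatter is expected in this assay, a step that the limit leaves unreadable from compound 1 to compound 4. Compound 4 is therefore estimated at 60000 nM, within 30000 nM to 150000 nM, with a fair chance that only a limit is reported.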

Compound 4, half-maximal effective concentration: 23000 nM
For compound 4 the middle estimate is 2.6-fold (0.42 log units) above the measured one; the whole stated range lies above it.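

In this assay this position does respond to the group placed on it: the exchange gives an at least 2.1-fold lower number from compound 1 to compound 4 (0.33 log units; beyond the scatter). Shifting the fluorine alone on the phenyl ring gives a 2.4-fold lower number from compound 3 to compound 4 (0.38 log units; beyond the scatter), so the place of the fluorine counts here, and not only the exchange of the pyridine ring for a phenyl ring. Steps to compound 2 still cannot be read: the limit of > 50000 nM in this assay, at which 2 of the 4 values shown sit.

As far as these compounds go, whether a 4-fluorophenyl, or a phenyl carrying an amine or a carboxylic acid, would lower the number further stays open. So does what an unsubstituted phenyl would give at this position.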